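Taking one bromo off a compound stuck at a limit

This account rests on a few compounds, and the source may have more. Where it says the series, first, only, none or still open, it means among the compounds named here.

In a functional assay on Caco-2 cells (Homo sapiens) for inhibition, read by MTT assay, with a stated time of 48 h (a higher number here means a weaker inhibitor, a lower number a stronger inhibitor), compound 2 `COc1ccccc1-c1csc(N/N=C/c2cc(OC)c(OC)c(Br)c2Br)n1` gives > 100000 nM, which is a limit and not a number. Compound 3 `COc1cc(/C=N/Nc2nc(-c3ccc(Br)cc3)cs2)c(Br)c(Br)c1OC` gives > 100000 nM, also a limit. Among the compounds with values here, the one measured step that touches compound 2 is a step that the two limits leave unreadable from compound 2 to compound 3, so it offers no size to borrow. Compound 4 `COc1ccccc1-c1csc(N/N=C/c2cc(Br)c(OC)c(OC)c2)n1` differs from compound 2 by hydrogen in place of bromo on an aromatic carbon. Within the data shown here, the only true number comes from compound 1 `COc1cc(/C=N/Nc2nc(-c3ccc(F)c(F)c3)cs2)cc(Br)c1OC` at 21200 nM, so a step toward stronger inhibition in this assay is expected, though only loosely. The expected step is an at least 2.2-fold lower number from compound 2 to compound 4 (0.34 log units; beyond the scatter). For compound 4 the estimated value is 45000 nM, with an expected range of 15000 nM to 100000 nM.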

Compound 4, half-maximal inhibitory concentration: > 100000 nM
Compound 4 ended at the assay's limit (the forecaster's own chance of this, stated with the estimate: 35%); middle value at least 2.2-fold (0.34 log units) from the limit.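

Taking off the bromo does not bring the result into readable range in this assay: compound 4 gives > 100000 nM, which is still a limit, so its step from compound 2 cannot be read. The aryl group is what separates the readable result from the limit, with an at least 4.7-fold higher number from compound 1 to compound 4 (0.67 log units; beyond the scatter) when 2-methoxyphenyl replaces 3,4-difluorophenyl. Most of this small set gives no number to compare: the limit of > 100000 nM in this assay, at which 3 of the 4 values shown sit.

Still open, from the compounds shown here alone, is what this bromo does when 3,4-difluorophenyl is present. It is also unknown whether an amine on the 2-methoxyphenyl ring would give a readable number.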